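Swapping nitro for methyl on the triazole-linked phenyl ring

A few compounds are considered here, and "the series" means these few. Any claim that something is new, unique, unknown or untested is made for them only; others in the source may bear on it.

Measured so far:
- compound 1 `COc1cc(/C=C/C(C)=O)ccc1OCc1cn(-c2ccc(/N=N/c3ccccc3)cc2)nn1`: 42100 nM
- compound 2 `COc1ccc(-n2cc(COc3ccc(/C=C/C(C)=O)cc3OC)nn2)cc1`: 2010 nM
- compound 3 `COc1cc(/C=C/C(C)=O)ccc1OCc1cn(-c2ccc([N+](=O)[O-])cc2)nn1`: 46700 nM

In a functional assay on PC-3 cells (Homo sapiens) for antiproliferative activity, read by MTT assay, with a stated time of 48 h (on this read-out higher numbers stand for weaker inhibition and lower numbers for stronger inhibition), compound 3 stands at the highest number of the three, close to compound 1 and far from compound 2. Compound 4 `COc1cc(/C=C/C(C)=O)ccc1OCc1cn(-c2ccc(C)cc2)nn1` differs from compound 3 by methyl in place of nitro on an aromatic carbon. The step that bears most on this change is a 23-fold higher number from compound 2 to compound 3 (1.37 log units; beyond the scatter), where a small neutral group was replaced by nitro; the step of a 1.1-fold higher number from compound 1 to compound 3 (0.05 log units; within the scatter) shows that a large ring and nitro sit at similar numbers. Methyl, like methoxy, is a small uncharged group, so compound 4 is expected to give a markedly lower number than compound 3, a 7.8-fold lower number from compound 3 to compound 4 (0.89 log units; beyond the scatter), though a methyl may not reach what methoxy gave. The estimate for compound 4 is 6000 nM, within 1500 nM to 25000 nM.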

Compound 4, half-maximal inhibitory concentration: 58100 nM
Compound 4: the middle estimate sits 9.7-fold (0.99 log units) below what was measured; the measured number lies above the stated range.
By their numbers in this assay, from the lowest: compound 2; then compounds 1, 3 and 4 (each within the scatter of the next).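

In this assay, methyl in place of nitro leaves the number unchanged within the scatter (a 1.2-fold higher number from compound 3 to compound 4 (0.09 log units; within the scatter)), and methyl in place of the large group of compound 1 does too (a 1.4-fold higher number from compound 1 to compound 4 (0.14 log units; within the scatter)). Methyl in place of methoxy, however, is a large step (a 29-fold higher number from compound 2 to compound 4 (1.46 log units; beyond the scatter)), so a small uncharged group at this position does not by itself give the low number of compound 2. Nothing available explains why methoxy stands apart.

From the compounds shown here alone, whether ethoxy, hydroxyl or an amine at this position would match methoxy or fall with the other three remains open.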